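Notes on a carboxy-for-trifluoromethyl swap in a benzylamine series

The compounds below may be only part of what the source reports. "The series", "measured", "known", "first", "only" and "open" are said of these compounds alone.

Measured so far:
Compound 1 `O=[N+]([O-])c1cccc(CNc2cc(C(F)(F)F)cc3[nH]ncc23)c1` gives 69% in an assay for inhibition of Indoleamine 2,3-dioxygenase 1 (Homo sapiens), with stated times of 10 min and 60 min, tested at 100 uM; a higher number here means a stronger effect of the compound at the concentration tested, a lower number a weaker effect.
Compound 2 `FC(F)(F)c1cccc(CNc2cc(C(F)(F)F)cc3[nH]ncc23)c1` gives 49% in this assay.

Going by the values given here, compound 2 stands lowest of the two numbers known in this assay; its nearest neighbour is compound 1, and the only step in the data, a number 20 percentage points lower from compound 1 to compound 2 (beyond the scatter), is modest but beyond the scatter.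

Compound 3 `O=C(O)c1cccc(CNc2cc(C(F)(F)F)cc3[nH]ncc23)c1` is the next compound to be measured. It differs from compound 2 by carboxy in place of trifluoromethyl on an aromatic carbon.

Among the compounds with values here, the one measured step concerns the same position and also exchanges the group sitting there, but it goes from nitro to trifluoromethyl, not from trifluoromethyl to carboxy. It therefore bears on the present change only in showing that a swap at this position moved the read-out by a modest amount. Within the data shown here, no measured pair contains a carboxy, so direction for compound 3 cannot be read from the data. On that basis the step of a number 9 percentage points lower from compound 2 to compound 3 (within the scatter) is expected to be small, with compound 3 placed near compound 2 and a wide range on either side. The estimate for compound 3 in this assay is 40%, between 15% and 68%.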

Compound 3, a percentage reported as inhibition, at one concentration (the size of the read-out at that concentration, not a potency): 17%
For compound 3 the middle estimate is 23 percentage points above the measured one; measured number inside the range.
By their numbers in this assay, from the lowest: compound 3; then compound 2; then compound 1.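

Exchange at this place, on an aromatic carbon meta to a large group, can move the read-out much further than the earlier pair showed: a number 32 percentage points lower from compound 2 to compound 3 (beyond the scatter) in this assay is a large step, where the only earlier step was modest. Measured against nitro, the carboxy change is larger still, with a number 52 percentage points lower from compound 1 to compound 3 (beyond the scatter) and compound 3 at the bottom of the set, so the three groups now fall in the order nitro, trifluoromethyl, carboxy, each step beyond the scatter. Trifluoromethyl and carboxy also differ in what is counted for them, since carboxy carries a hydrogen-bond donor and a hydrogen-bond acceptor and trifluoromethyl carries neither, but the drop cannot be tied to that difference from three compounds.

As far as these compounds go, whether a primary amide, a methyl ester or an aminomethyl group at this place would stay near compound 3 or rise towards compound 2 remains open, as does whether the same order of groups would hold on another core. No measurement on these compounds offers an explanation for the lower read-out of the carboxy compound.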